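From Chloro to Butyl on a Shared Aryl Keto-Acid Core

This account rests on a few compounds, and the source may have more. Where it says the series, first, only, none or still open, it means among the compounds named here.

Of the compounds shown here, three sharing one core have been measured in a functional assay on K562 cells (Homo sapiens) for inhibition, read by MTT assay, with a stated time of 72 h; a lower number here means a stronger inhibitor, a higher number a weaker inhibitor. Compound 1 `O=C(O)/C=C/C(=O)c1ccc(Cl)cc1Cl` gives 58500 nM. Compound 2 `O=C(O)/C=C/C(=O)c1ccc(Cl)cc1` gives 21700 nM, and compound 3 `O=C(O)/C=C/C(=O)c1ccc(Cl)c(Cl)c1` gives 23200 nM. Compound 2 holds the lowest of the three numbers; its nearest neighbour is compound 3, within the scatter, and its gap to compound 1 lies beyond it. The step of a 2.7-fold lower number from compound 1 to compound 2 (0.43 log units; beyond the scatter) is the only one beyond the scatter, while a 1.1-fold higher number from compound 2 to compound 3 (0.03 log units; within the scatter) changes nothing of note.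

Compound 4 `CCCCc1ccc(C(=O)/C=C/C(=O)O)cc1` has not yet been measured. Relative to compound 2 the change is butyl in place of chloro on an aromatic carbon. Neither measured step bears directly on this exchange: both concern a chloro on an aromatic carbon, and neither involves a butyl. The step from compound 1 to compound 2 shows that a chloro can matter, the step from compound 2 to compound 3 that it need not. With nothing closer to lean on, the step of a 1.2-fold lower number from compound 2 to compound 4 (0.08 log units; within the scatter) is expected to stay within or only just beyond the scatter, because compound 2 stands at 21700 nM and no measured change on this carbon exists. Compound 4 is estimated at 18000 nM, with a range from 6000 nM to 60000 nM.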

Compound 4, half-maximal inhibitory concentration: 4950 nM
Compound 4: middle estimate off by 3.6-fold (0.56 log units), on the high side, outside the stated range (below it).
By their numbers in this assay, from the lowest: compound 4; then compounds 2 and 3 (each within the scatter of the next); then compound 1.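

In this assay, the aromatic carbon para to a group of 7 heavy atoms responds to a change of group, with butyl in place of chloro giving a 4.4-fold lower number from compound 2 to compound 4 (0.64 log units; beyond the scatter). This is the first change shown at that carbon: the two earlier steps both kept this chloro and altered a chloro elsewhere on the six-membered aromatic ring, so they could not show how the number moves when the chloro itself leaves. The exchange takes out 1 chlorine and brings in 4 carbon atoms, with hydrogen-bond donors, hydrogen-bond acceptors and net charge all counted the same on both sides, but nothing shown here measures why the number falls with this exchange.

A single butyl cannot tell whether the number would keep falling with a longer chain such as hexyl, rise again with a shorter one such as ethyl, or shift with a branched chain such as tert-butyl, or with an amine or a carboxylic acid at this carbon. On these data alone, it also remains open whether a second chloro on the ring would have the same effect beside butyl as it has beside the chloro of compound 2.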